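This account rests on a few compounds, and the source may have more. Where it says the series, first, only, none or still open, it means among the compounds named here.

Compound 2 `COc1ccc(C(=O)/C(=C/c2ccc([N+](=O)[O-])cc2)CCOC(C)=O)cc1` belongs to a small set of three measured analogues that share one core and differ only in the group on the double-bonded chain carbon or on the ring it carries. In a functional assay on NB-4 cells (Homo sapiens) for inhibition, read by XTT assay, with a stated time of 48 h (a higher number here means a weaker inhibitor, a lower number a stronger inhibitor), compound 2 gives > 100000 nM, which is a limit of the assay rather than a number. Compound 2 thus sits at the limit of > 100000 nM in this assay, at which 2 of the 3 values shown sit. Compound 1 `COc1ccc(C(=O)/C(=C/C2CCCCC2)CCOC(C)=O)cc1` also gives a limit in this assay, namely > 100000 nM. For the measured compounds named here, compound 3 `COc1ccc(C(=O)/C(=C/c2ccc(Cl)cc2)CCOC(C)=O)cc1` is the only one with a number, giving 36300 nM in this assay, so the step of an at least 2.7-fold lower number from compound 2 to compound 3 (0.44 log units; beyond the scatter) can only be read as a bound.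

Compound 4 `CCN(CC)C/C(=C\c1ccc([N+](=O)[O-])cc1)C(=O)c1ccc(OC)cc1` differs from compound 2 by diethylamino in place of acetoxymethyl on a saturated chain carbon bound to a double-bonded chain carbon. Going by the values given here, none of the measured steps touches this part of the molecule: a step that the two limits leave unreadable from compound 1 to compound 2 and an at least 2.7-fold lower number from compound 1 to compound 3 (0.44 log units; beyond the scatter) exchange the group on the double-bonded chain carbon, and an at least 2.7-fold lower number from compound 2 to compound 3 (0.44 log units; beyond the scatter) exchanges a substituent on an aromatic carbon. Among the compounds with values here, no measured step therefore bears directly on the change to compound 4, and its starting point, compound 2, is known only as a limit. The step of an at least 2.5-fold lower number from compound 2 to compound 4 (0.39 log units; beyond the scatter) is an estimate with wide uncertainty. Compound 4 is expected to give 40000 nM in this assay, within a range of 5000 nM to 200000 nM.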

Compound 4, half-maximal inhibitory concentration: 1200 nM
Beside the measured number, compound 4's estimate is 33-fold (1.52 log units) above it; measured number outside the range, below it.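

Moving from the group on the double-bonded chain carbon to the saturated chain carbon bound to it reveals a position that matters strongly in this assay: putting diethylamino in place of acetoxymethyl gives an at least 83-fold lower number from compound 2 to compound 4 (1.92 log units; beyond the scatter). Compound 4 keeps the 4-nitrophenyl group of compound 2, so carrying that group does not by itself keep a compound of this set from giving a measurable number. The step is only a bound, and the real change may be larger, since compound 2 stands at a limit of the assay rather than at a number: the limit of > 100000 nM in this assay, at which 2 of the 4 values shown sit.

The compounds shown leave open whether this change depends on the particular diethylamino group or would also appear with another amine, such as dimethylamino, piperidine or morpholine, or with a longer chain ending in an amine. They also leave open whether diethylamino would bring a similar change when paired with the 4-chlorophenyl group of compound 3 or the cyclohexyl group of compound 1.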